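Bromo for hydrogen on the aromatic ring of compound 2

This account rests on a few compounds, and the source may have more. Where it says the series, first, only, none or still open, it means among the compounds named here.

Of the compounds shown here, three share one core and have been tested in a functional assay on A549 cells (Homo sapiens) for cytotoxicity, with a stated time of 48 h; on this read-out higher numbers stand for weaker inhibition and lower numbers for stronger inhibition. Compound 1 `Cc1ccc2c(=O)cc(/C=C/[S+](C)[O-])oc2c1` gives 2000 nM. Compound 2 `C[S+]([O-])/C=C/c1cc(=O)c2ccccc2o1` gives 1900 nM, the second highest of the three numbers; its nearest neighbour is compound 1 and its furthest is compound 3. Compound 3 `Cc1c(/C=C/[S+](C)[O-])oc2ccccc2c1=O` gives 1500 nM.

The new compound 4 `C[S+]([O-])/C=C/c1cc(=O)c2cc(Br)ccc2o1` is compound 2 with bromo in place of hydrogen on an aromatic carbon. The change sits on an aromatic carbon of a six-membered aromatic ring of carbon only, part of a fused or bridged system of two rings, meta to a fused ring and para to a fused ring.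

Among the compounds with values here, two measured steps bear on it, both exchanges of a small group for hydrogen on an aromatic carbon of the same core. The step of a 1.1-fold lower number from compound 1 to compound 2 (0.02 log units; within the scatter) and the step of a 1.3-fold lower number from compound 2 to compound 3 (0.10 log units; within the scatter) both stay within the scatter. Within the data shown here, no step with bromo has been measured, so the expectation rests on these two. Compound 4 is therefore expected to sit close to compound 2, with a 1.1-fold lower number from compound 2 to compound 4 (0.05 log units; within the scatter) as the expected step. The estimate for compound 4 is 1700 nM, with a range from 800 nM to 3600 nM.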

Compound 4, half-maximal inhibitory concentration: 1100 nM
Compound 4: middle estimate off by 1.5-fold (0.19 log units), on the high side; low and high end bracket the measured number.
By their numbers in this assay, from the lowest: compounds 4, 3, 2 and 1 (each within the scatter of the next).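

In this assay, bromo in place of hydrogen gives a 1.7-fold lower number from compound 2 to compound 4 (0.24 log units; within the scatter), so this aromatic carbon, meta to a fused ring and para to a fused ring, carries a bromine atom without the number moving beyond the usual scatter. Within the data shown here, the earlier steps, a 1.1-fold lower number from compound 1 to compound 2 (0.02 log units; within the scatter) and a 1.3-fold lower number from compound 2 to compound 3 (0.10 log units; within the scatter), concerned methyl alone, so this is the first view of a halogen on the shared core, and although its step is the largest of the three, it too stays within the scatter. Nothing available explains the size of this step or says what the bromine atom contributes to it.

At this carbon the compounds shown hold only hydrogen and bromo, so they give no trend for the position and cannot say whether any group placed there would shift the number beyond the scatter. On these data alone, how fluoro, an amine, a carboxylic acid or a longer chain such as propyl would behave on this carbon remains open, as does whether bromo on other carbons of the same ring would match this result.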